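The compounds below may be only part of what the source reports. "The series", "measured", "known", "first", "only" and "open" are said of these compounds alone.

Measured compounds:
compound 1 `Cc1cccc2cc3c(nc12)-c1nc2ccccc2n1C3`: 20000 nM
compound 2 `Cc1ccc2nc3c(cc2c1)Cn1c-3nc2ccccc21`: 11300 nM
compound 3 `COc1cccc2cc3c(nc12)-c1nc2ccccc2n1C3`: 16900 nM

All three were run in a functional assay on KB cells (Homo sapiens) for cytotoxicity, read by MTT assay, with a stated time of 72 h; on this read-out higher numbers stand for weaker inhibition and lower numbers for stronger inhibition. Compound 2 and compound 1 are built from the same atoms joined differently; the difference between the two cores is not broken down here. The three values lie within the scatter of one another, so no order among them is claimed.

The change from compound 1 to compound 3 is methoxy in place of methyl on an aromatic carbon and gave a 1.2-fold lower number from compound 1 to compound 3 (0.07 log units; within the scatter). Compound 4 `COc1ccc2nc3c(cc2c1)Cn1c-3nc2ccccc21` carries the same kind of change on the core of compound 2, (methoxy in place of methyl on an aromatic carbon); the place differs in that the substituted carbon is meta to a fused ring and para to a fused ring, rather than ortho to a fused ring and meta to a fused ring. For compound 4 a step of similar size is expected in this assay, a 1.2-fold lower number from compound 2 to compound 4 (0.08 log units; within the scatter), resting on the earlier step of a 1.2-fold lower number from compound 1 to compound 3 (0.07 log units; within the scatter) having stayed within the scatter. Compound 4 is therefore estimated at 9500 nM, with a likely range from 5000 nM to 20000 nM.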

Compound 4, half-maximal inhibitory concentration: 20000 nM
Beside the measured number, compound 4's estimate is 2.1-fold (0.32 log units) below it; measured number inside the range.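

In this assay, methoxy in place of methyl gives a 1.8-fold higher number from compound 2 to compound 4 (0.25 log units; within the scatter). Set beside the earlier step, the change does not separate the two cores: the same change on two cores in this assay, a 1.2-fold lower number (0.07 log units; within the scatter) from compound 1 to compound 3 and a 1.8-fold higher number (0.25 log units; within the scatter) from compound 2 to compound 4, 2.1-fold (0.32 log units) apart, within the scatter of two such steps. This supports carrying the change between these two cores and places without a detectable difference in this read-out, but with each step inside the scatter it shows no effect of the change on either core and gives no rule for other cores or places.

The compounds shown carry only methyl and methoxy on the aromatic carbon. On these data alone, whether an amine, a carboxylic acid or a longer chain there would give a step beyond the scatter remains open.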